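Methoxy Additions on Two Styryl Cores and Growth Inhibition

A few compounds are considered here, and "the series" means these few. Any claim that something is new, unique, unknown or untested is made for them only; others in the source may bear on it.

Compound 1, `O=c1ccoc(/C=C/c2ccccc2)c1`, 691 uM
Compound 2, `COc1ccc(/C=C/c2cc(=O)cco2)cc1`, 396 uM
Compound 3, `COc1ccc(/C=C/C2CC=CC(=O)N2)cc1`, > 1090 uM

In a functional assay on MCF7 cells (Homo sapiens) for inhibition, read by sulforhodamine B assay, with a stated time of 48 h (a lower number here means a stronger inhibitor of growth, a higher number a weaker inhibitor of growth), compound 1 gives 691 uM. Compound 2 differs from it by methoxy in place of hydrogen on an aromatic carbon, and in this assay compound 2 gives 396 uM, a step of a 1.7-fold lower number from compound 1 to compound 2 (0.24 log units; within the scatter). Compound 3 carries a different core; how the two cores differ is not broken down here. Compound 3 gives only a limit in this assay, > 1090 uM, which is a limit of the measurement and not a number, as recorded at the limit of > 1090 uM in this assay, at which 1 of the 3 values shown sits.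

Compound 4, `COc1ccc(/C=C/C2CC=CC(=O)N2)cc1OC`, has not been measured. It differs from compound 3 by methoxy in place of hydrogen on an aromatic carbon. This is the same kind of change as that from compound 1 to compound 2, but not the same: in the earlier pair the methoxy enters para to a group of 9 heavy atoms, whereas here it enters ortho to a methoxy group and meta to a group of 9 heavy atoms.

Since the step from compound 1 to compound 2 lay within the scatter, and since compound 3 stands at a limit in this assay, compound 4 is expected to give a result close to that of compound 3, a step estimated at a step that the limit leaves unreadable from compound 3 to compound 4. The estimate for compound 4 in this assay is 1200 uM, expected to fall between 500 uM and 3000 uM.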

Compound 4, concentration for growth inhibition (reported as GI): > 964 uM
Compound 4 ended at the assay's limit; the forecaster's own chance of this, stated with the estimate: 70%; the middle value is on the limit's open side.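

In this assay compound 4 gives > 964 uM, which is a limit of the assay and not a number. Compound 3 gives > 1090 uM, which is also a limit. With both compounds at limits, the step between compound 3 and compound 4 cannot be read. The compounds shown leave open what the added methoxy does on the core of compound 3, and whether it acts there as it does on the core of compound 1.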